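Adding a ring acetoxy to compound 2

This account rests on a few compounds, and the source may have more. Where it says the series, first, only, none or still open, it means among the compounds named here.

Within the data shown here, two results anchor the series so far. Compound 1 (`CCCC[C@@H](/C=C\[C@@H]1OC(=O)C[C@@H](OC)[C@@H]1O)OC(C)=O`) gives > 20 ug/mL in a functional assay on SK-MEL-2 cells (Homo sapiens) for cytotoxicity, read by sulforhodamine B assay, with a stated time of 72 h (a higher number here means that more compound is needed for the effect, a lower number that less compound is needed), as a limit of the assay and not a number. Among the measured compounds shown here, compound 2 (`CCCC[C@H](OC(C)=O)[C@@H](OC(C)=O)[C@H](OC(C)=O)[C@H]1CC=CC(=O)O1`) gives 3.3 ug/mL in this assay and so holds the only actual number available. Compounds 1 and 2 differ in more than one place, so their two results do not isolate any single structural change.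

The next structure is compound 3 (`CCCC[C@H](OC(C)=O)[C@@H](OC(C)=O)[C@H](OC(C)=O)[C@@H]1OC(=O)C=C[C@@H]1OC(C)=O`). The change from compound 2 is acetoxy in place of hydrogen on a saturated ring carbon and sits next to the ring atom that bears a large group, two ring bonds from the ring oxygen. For the measured compounds named here, no measured pair tests this change, so the expectation rests on compound 2 at 3.3 ug/mL as the sole numerical reference. The estimated move a 1.4-fold higher number from compound 2 to compound 3 (0.13 log units; within the scatter) is expected to stay within the usual scatter, with a slight lean toward more compound being needed. For compound 3 the expected value is 4.5 ug/mL with an estimated range from 1.2 ug/mL to 17 ug/mL as the working bracket.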

Compound 3, concentration for half-maximal effect: 4.5 ug/mL
Estimate against measurement, compound 3: no gap at the digits printed; the range from low to high includes it.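

In this assay the first pair differing in one place gives a 1.4-fold higher number from compound 2 to compound 3 (0.13 log units; within the scatter), so acetoxy in place of hydrogen on a saturated ring carbon, next to the ring atom that bears a large group and two ring bonds from the ring oxygen, is tolerated in this read-out. Among these compounds, this is something compound 1 and compound 2 could not show, as they differ in more than one place, and it means that this position accepts the acetoxy group with no step that can be told from the scatter. Compound 3 also gives an actual number and not a limit, so the series still holds a single limit: the limit of > 20 ug/mL in this assay, at which 1 of the 3 values shown sits.

Going by these compounds, whether the same position accepts other groups stays open, since one acetoxy step says nothing about an amine or a benzoyloxy group placed there. Steps from compound 1 to the other compounds cannot be read, and what separates its limit from the numbers of compound 2 and compound 3 remains unassigned to any single structural feature.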